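Swapping a Hydroxy Group for a Triazolyl Sulfide

This account rests on a few compounds, and the source may have more. Where it says the series, first, only, none or still open, it means among the compounds named here.

Three sugar-derived compounds were tested in a functional assay on HBL-100 cells (Homo sapiens) for antiproliferative activity, read by sulforhodamine B assay, with a stated time of 48 h; on this read-out lower numbers stand for stronger inhibition of growth and higher numbers for weaker inhibition of growth. Compound 1 `CC1(C)O[C@H]2[C@H](OCc3noc(-c4ccc([N+](=O)[O-])cc4)n3)O[C@H](CO)[C@H]2O1` gives 99000 nM in this assay. Compound 3 `COc1cc(-c2cc(CO[C@@H]3O[C@H](CSc4ncn[nH]4)[C@H]4OC5(CCCC5)O[C@@H]34)on2)cc(OC)c1OC`, which also carries a (1H-1,2,4-triazol-5-yl)sulfanyl group on a saturated chain carbon bound to a saturated ring carbon, gives 87000 nM in this assay, a number that sits within the usual scatter of the value for compound 1, so the two cannot be told apart. Compound 2 `Cc1ccc(S(=O)(=O)OC[C@H]2O[C@@H](OCc3noc(-c4ccc([N+](=O)[O-])cc4)n3)[C@@H]3OC4(CCCC4)O[C@@H]32)cc1` returned only a limit of the assay, > 100000 nM, rather than a number. Compound 1 thus stands at one of the two numbers shown, both weak, with a third compound at the limit (the limit of > 100000 nM in this assay, at which 1 of the 3 values shown sits).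

Compound 4 `CC1(C)O[C@H]2[C@H](OCc3noc(-c4ccc([N+](=O)[O-])cc4)n3)O[C@H](CSc3ncn[nH]3)[C@H]2O1` has not been measured. It differs from compound 1 in one place: (1H-1,2,4-triazol-5-yl)sulfanyl in place of hydroxy on a saturated chain carbon bound to a saturated ring carbon. Within the data shown here, no measured pair shows the effect of exactly this change. Since compound 3 carries the same entering group and gives 87000 nM in this assay, the step from compound 1 is expected to be small, within the scatter, in either direction: a 1.1-fold lower number from compound 1 to compound 4 (0.04 log units; within the scatter). Compound 4 is therefore expected to give about 90000 nM in this assay, with a likely range from 40000 nM to 200000 nM.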

Compound 4, concentration for 50% growth inhibition: > 100000 nM
Compound 4 was reported as a limit; the forecaster's own chance of this, stated with the estimate: 35%; at least 1.1-fold (0.04 log units) between middle value and limit.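

Putting (1H-1,2,4-triazol-5-yl)sulfanyl in place of hydroxy on a saturated chain carbon bound to a saturated ring carbon can now be read as a direct step in this assay: it gives a number no lower from compound 1 to compound 4 (the limit leaves the size open). The earlier compounds shown here offered no pair that differed only in this one place, and this first pair shows that the larger, ring-bearing group does not bring a lower number, so it adds no measurable growth inhibition to the weak activity of the hydroxy compound. The result for compound 4 is a limit of the assay and not a number, and it shares that limit with one other compound: the limit of > 100000 nM in this assay, at which 2 of the 4 values shown sit.

The size of the step cannot be read, so the compounds shown do not settle whether this change weakens growth inhibition or leaves it about where it was. They also leave open whether an amine or a carboxylic acid in place of hydroxy on this same saturated chain carbon would give a lower number than compound 1 does in this assay.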